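A few compounds are considered here, and "the series" means these few. Any claim that something is new, unique, unknown or untested is made for them only; others in the source may bear on it.

Compound 1 `Cc1nc(N)c2nc(-c3ccccc3)sc2n1` and compound 2 `COc1ccc(-c2nc(N)c3nc(-c4ccccc4)sc3n2)cc1` share one core and differ only in the group on it. In an assay on CHO cells for displacement of a labelled ligand from adenosine receptor A3 (Homo sapiens), read by scintillation counting, with a stated time of 3 h (a higher number here means a weaker inhibitor, a lower number a stronger inhibitor), compound 1 gives 2660 nM, while compound 2 gives 46.7 nM; the change of a methyl for a 4-methoxyphenyl on an aromatic carbon brought a 57-fold lower number from compound 1 to compound 2 (1.76 log units; beyond the scatter). Compound 2 thus stands as the stronger of the two measured compounds in this assay, and compound 3 `COc1cccc(-c2nc(N)c3nc(-c4ccccc4)sc3n2)c1` is built from it by 3-methoxyphenyl in place of 4-methoxyphenyl on an aromatic carbon. Within the data shown here, no measured step moves the methoxy group around the ring; the single measured step concerns a different exchange, so it gives only an indirect guide. The expected step is a 1.8-fold higher number from compound 2 to compound 3 (0.26 log units; within the scatter), a modest weakening that may well sit inside the scatter. For compound 3 the estimate in this assay is 85 nM. The expected range for compound 3 runs from 25 nM to 300 nM.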

Compound 3, inhibition constant: 35.6 nM
Compound 3: middle estimate off by 2.4-fold (0.38 log units), on the high side; the measured number falls inside the stated range.
By their numbers in this assay, from the lowest: compounds 3 and 2 (each within the scatter of the next); then compound 1.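

In this assay, the shift from 4-methoxyphenyl to 3-methoxyphenyl on the aromatic carbon between two ring nitrogen atoms gives a 1.3-fold lower number from compound 2 to compound 3 (0.12 log units; within the scatter), so this assay does not tell the two placements of the methoxy group apart. The large gain seen on replacing methyl is therefore not confined to 4-methoxyphenyl: the exchange for 3-methoxyphenyl gives a 75-fold lower number from compound 1 to compound 3 (1.87 log units; beyond the scatter), and neither methoxyphenyl compound goes against this. No supporting measurement is available to explain these results.

The compounds shown leave open whether the methoxy group contributes at all, as opposed to the phenyl ring alone, which an unsubstituted phenyl at this carbon would test. They also leave open how a hydroxyl, an amine or a longer ethoxy group on that ring would compare.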